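The compounds below may be only part of what the source reports. "The series", "measured", "known", "first", "only" and "open" are said of these compounds alone.

Compound 1 `Cc1nc2cc(-c3ccccc3)nn2c(-c2cc(F)c3c(c2C)CCCO3)c1C(OC(C)(C)C)C(=O)O` gives 97% in an ADME assay on microsomes from liver (Rattus norvegicus), read by LC-MS, using NADPH, with a stated time of 10 min, tested at 0.5 uM; on this read-out higher numbers stand for a more stable compound and lower numbers for a less stable compound. Compound 2 `Cc1ccc(-c2cc3nc(C)c(C(OC(C)(C)C)C(=O)O)c(-c4cc(F)c5c(c4C)CCCO5)n3n2)cc1` gives 94% in this assay, and the step of a number 3 percentage points lower from compound 1 to compound 2 (within the scatter) goes with the change (methyl in place of hydrogen on an aromatic carbon). Compound 3 `Cc1nc2cc(-c3cccc(-c4ccccc4)c3)nn2c(-c2cc(F)c3c(c2C)CCCO3)c1[C@H](OC(C)(C)C)C(=O)O` gives 96% in this assay; how its core differs from the core of compound 1 is not broken down here. Compound 4 `Cc1ccccc1-c1cccc(-c2cc3nc(C)c([C@H](OC(C)(C)C)C(=O)O)c(-c4cc(F)c5c(c4C)CCCO5)n3n2)c1` has not yet been measured in this assay. It differs from compound 3 by methyl in place of hydrogen on an aromatic carbon, which is the same kind of change as that made from compound 1 to compound 2, though the methyl enters ortho to a large group in compound 4 and para to a large group in compound 2. For compound 4 the step of a number 1 percentage points lower from compound 3 to compound 4 (within the scatter) is expected to stay within the scatter, because the earlier change gave only a number 3 percentage points lower from compound 1 to compound 2 (within the scatter) and compound 3 already stands at 96%. Compound 4 is therefore estimated at 95%, expected to fall between 87% and 100%.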

Compound 4, percent of the compound remaining: 97%
Beside the measured number, compound 4's estimate is 2 percentage points below it; measured number inside the range.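

In this assay, methyl in place of hydrogen gives a number 1 percentage points higher from compound 3 to compound 4 (within the scatter), and the two steps for this change do not differ: the same change on two cores in this assay, a number 3 percentage points lower (within the scatter) from compound 1 to compound 2 and a number 1 percentage points higher (within the scatter) from compound 3 to compound 4, 4 percentage points apart, within the scatter of two such steps. Within these two pairs, the change can therefore be carried from one core to the other without a step beyond the scatter. This does not show that it would carry to a core with a lower percentage remaining, as all four compounds here have high values, nor does it separate any effect of where the methyl sits.

From the compounds shown here alone, it remains open whether an amine or a nitrile in place of the methyl would give the same result. Going by these compounds, whether the 2-methylphenyl result holds on other cores also remains open.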